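The source may report more compounds than this note shows. Statements on the series, on what has been measured and on what is new or still open speak of the compounds shown alone.

Measured in a functional assay on HT-29 cells (Homo sapiens) for inhibition, read by MTT assay, with a stated time of 48 h; on this read-out higher numbers stand for weaker inhibition and lower numbers for stronger inhibition:
- compound 1 `COc1cc(-c2nnc(SC)n2-c2ccc(N(C)C)cc2)cc(OC)c1OC`: > 60000 nM (a limit)
- compound 2 `CCSc1nnc(-c2cc(OC)c(OC)c(OC)c2)n1-c1ccc(N(C)C)cc1`: > 60000 nM (a limit)

Compound 2 has no number, only the limit > 60000 nM. Among the measured compounds shown here, the series so far stands at the limit of > 60000 nM in this assay, at which 2 of the 2 values shown sit.

Compound 3 `COc1cc(-c2nnc(SCc3ccc(F)cc3)n2-c2ccc(N(C)C)cc2)cc(OC)c1OC` changes the sulfur chain: 4-fluorophenyl in place of methyl on a saturated chain carbon bound to a sulfur.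

For the measured compounds named here, the one measured step at this place is a step that the two limits leave unreadable from compound 1 to compound 2. Its size cannot be read, so it sets no size or direction for the new change in this assay. Only a small move towards stronger inhibition, or none, is expected.

The estimated step is an at least 1.5-fold lower number from compound 2 to compound 3 (0.17 log units; that floor lies within the scatter).

For compound 3 the expected value is 40000 nM, with an estimated range of 8000 nM to 60000 nM.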

Compound 3, half-maximal inhibitory concentration: 44300 nM
Compound 3: middle estimate off by 1.1-fold (0.04 log units), on the low side; low and high end bracket the measured number.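

In this assay, among the compounds shown here, the 4-fluorobenzyl group on the sulfur gives the first readable number, and with it an at least 1.3-fold lower number from compound 2 to compound 3 (0.13 log units; that floor lies within the scatter) and an at least 1.3-fold lower number from compound 1 to compound 3 (0.13 log units; that floor lies within the scatter). As far as these compounds go, both steps are floors only, so their true size remains unknown. The step between the methyl and ethyl compounds cannot be read, with both at a limit: the limit of > 60000 nM in this assay, at which 2 of the 3 values shown sit.

From the compounds shown here alone, it remains open whether the fluorine or the aromatic ring accounts for the number, which an unsubstituted benzyl group would help separate. Going by these compounds, the effect of an amine or a carboxylic acid on the sulfur chain is also open.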